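Where the Trifluoromethyl Sits: Predicting Compound 4

The compounds below may be only part of what the source reports. "The series", "measured", "known", "first", "only" and "open" are said of these compounds alone.

Measured compounds:
compound 1, `Oc1cccc(-c2cc(-c3cccc(C(F)(F)F)c3)cc(-c3ccccc3O)n2)c1`, 13000 nM
compound 2, `Oc1cccc(-c2cc(-c3ccc(C(F)(F)F)cc3)cc(-c3ccccc3O)n2)c1`, a limit of > 50000 nM
compound 3, `Oc1ccc(-c2cc(-c3cccc(C(F)(F)F)c3)cc(-c3cccc(O)c3)n2)cc1`, 11100 nM

In a functional assay on DU-145 cells (Homo sapiens) for inhibition (on this read-out lower numbers stand for stronger inhibition and higher numbers for weaker inhibition), compound 1 gives 13000 nM. For compound 2 this assay reports only a limit, > 50000 nM. Compound 3 gives 11100 nM.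

From compound 1 to compound 2 the change is 4-(trifluoromethyl)phenyl in place of 3-(trifluoromethyl)phenyl on an aromatic carbon, and it made an at least 3.8-fold higher number from compound 1 to compound 2 (0.58 log units; beyond the scatter). The two cores differ as 4-hydroxyphenyl in place of 2-hydroxyphenyl on an aromatic carbon, a change that made a 1.2-fold lower number from compound 1 to compound 3 (0.07 log units; within the scatter).

Compound 4, `Oc1ccc(-c2cc(-c3ccc(C(F)(F)F)cc3)cc(-c3cccc(O)c3)n2)cc1`, has not yet been measured. It differs from compound 3 by 4-(trifluoromethyl)phenyl in place of 3-(trifluoromethyl)phenyl on an aromatic carbon. The surroundings are not identical: in compound 1 the place is meta to a 2-hydroxyphenyl group and meta to a 3-hydroxyphenyl group, while in compound 3 it is meta to a 3-hydroxyphenyl group and meta to a 4-hydroxyphenyl group, so this is the same kind of change rather than the same one.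

Because an at least 3.8-fold higher number from compound 1 to compound 2 (0.58 log units; beyond the scatter) and because of the limit of > 50000 nM in this assay, at which 1 of the 3 values shown sits, the step from compound 3 to compound 4 is expected to be a 4.5-fold higher number from compound 3 to compound 4 (0.65 log units; beyond the scatter), and the result may again be only a limit. Compound 4 is estimated at 50000 nM, between 25000 nM and 100000 nM.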

Compound 4, half-maximal inhibitory concentration: > 50000 nM
Compound 4: no number, only a limit (the forecaster's own chance of this, stated with the estimate: 55%); the middle value lies on the limit itself.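

Compound 4 is reported only as a limit, > 50000 nM. In this assay, on these data alone, putting 4-(trifluoromethyl)phenyl in place of 3-(trifluoromethyl)phenyl gives an at least 4.5-fold higher number from compound 3 to compound 4 (0.65 log units; beyond the scatter), so the change weakens inhibition on both cores, and it carries over in direction from the core of compound 1 to the core of compound 3: the same change on two cores in this assay, an at least 3.8-fold higher number (0.58 log units; beyond the scatter) from compound 1 to compound 2 and an at least 4.5-fold higher number (0.65 log units; beyond the scatter) from compound 3 to compound 4; the limit leaves it open whether they differ How large the change truly is on either core remains unknown, and the step from compound 2 to compound 4 cannot be read, as both values are limits.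

The compounds shown leave open whether the same weakening would appear with a chlorine atom or a methoxy group in place of the trifluoromethyl group. They also leave open whether a compound carrying 4-(trifluoromethyl)phenyl could give a true number in this assay if its hydroxyl groups were replaced, for example by an amine or a carboxylic acid.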